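Reverting the ring nitrogen from amino to an aryl group

A few compounds are considered here, and "the series" means these few. Any claim that something is new, unique, unknown or untested is made for them only; others in the source may bear on it.

Among the measured compounds shown here, compound 2 `NN1C(=O)C(c2ccccc2)CC(c2ccccc2)C1=O` shows the higher of the two numbers so far in a functional assay on the whole organism (strain Swiss albino) for inhibition, with Mus musculus as the target, in the maximal electroshock model, with a stated time of 2 h, at a dose of 25 mg/kg by the intraperitoneal route (on this read-out higher numbers stand for more inhibition at the one dose given (going by the name of the read-out) and lower numbers for less inhibition), giving 76%. For the measured compounds named here, compound 1 `O=C1C(c2ccccc2)CC(c2ccccc2)C(=O)N1c1ccccc1` gives 38.3% in this assay, and the one step between them, a number 37.7 percentage points higher from compound 1 to compound 2 (beyond the scatter), is the whole of the measured evidence. Compound 3 `Cc1ccccc1N1C(=O)C(c2ccccc2)CC(c2ccccc2)C1=O` carries 2-methylphenyl in place of amino on an amide-type nitrogen in a ring. Going by the values given here, this change largely undoes the one that separates compound 1 from compound 2: an aryl group again takes the place of the amino group on the amide-type nitrogen in the ring, with a methyl added. Since the move from phenyl to amino raised the number by a large margin, the reverse move is expected to lower it by a comparable amount, landing near where compound 1 stands. The expected step is a number 36 percentage points lower from compound 2 to compound 3 (beyond the scatter). Compound 3 is therefore estimated at 40%, with a range from 18% to 65%.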

Compound 3, a percentage reported as inhibition, in the whole organism at one dose (the size of the read-out at that dose, not a potency): 66.1%
The estimate for compound 3 lay 26.1 percentage points below the measured number, outside the stated range (above it).
By their numbers in this assay, from the lowest: compound 1; then compounds 3 and 2 (each within the scatter of the next).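

In this assay, the amino group on the amide-type nitrogen in the ring can give way to 2-methylphenyl with a number 9.9 percentage points lower from compound 2 to compound 3 (within the scatter), so an amino group is not required on this nitrogen for a number of this size. An aryl group there does not fix the number either: methyl in place of hydrogen on an aromatic carbon gives a number 27.8 percentage points higher from compound 1 to compound 3 (beyond the scatter), a clear separation for so small a change. No data at hand account for this separation.

The compounds shown leave open whether the methyl itself matters or whether another small group, such as chlorine or methoxy, would serve in its place. They also leave open how a longer chain, such as ethyl, would fare at that place, and how a methylamino group would compare with the amino group on the nitrogen.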